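This account rests on a few compounds, and the source may have more. Where it says the series, first, only, none or still open, it means among the compounds named here.

Measured in a functional assay on HepG2 cells (Homo sapiens) for inhibition, read by MTT assay, with a stated time of 72 h; a higher number here means a weaker inhibitor, a lower number a stronger inhibitor:

Compound 1 `CC(C)CCN(CCCCCC(=O)NO)c1ncc(C(=O)NCCCn2ccnc2)s1`: 106000 nM
Compound 2 `O=C(/C=C/c1ccc(CN(Cc2ccc(F)cc2)c2ncc(C(=O)NCCCn3ccnc3)s2)cc1)NO`: 13000 nM
Compound 3 `CC(C)CCN(CCCCCCC(=O)NO)c1ncc(C(=O)NCCCn2ccnc2)s1`: 24000 nM

Compound 2 and compound 3 lie within the scatter of each other, and both numbers are lower than that of compound 1. Compound 4 `O=C(NO)c1ccc(CN(Cc2ccc(F)cc2)c2ncc(C(=O)NCCCn3ccnc3)s2)cc1` differs from compound 2 by hydroxycarbamoyl in place of 2-(hydroxycarbamoyl)ethenyl on an aromatic carbon, with hydroxycarbamoyl in place of 2-(hydroxycarbamoyl)ethenyl on an aromatic carbon, para to a large group. Among the compounds with values here, only one measured step bears on this, and loosely, as it lies on a saturated chain: a 4.4-fold lower number from compound 1 to compound 3 (0.65 log units; beyond the scatter). There, the longer group carried the lower number, and compound 4 carries the shorter group. A modest rise in this assay is therefore expected, estimated as a 2.2-fold higher number from compound 2 to compound 4 (0.33 log units; beyond the scatter). For compound 4 the estimated value is 28000 nM, with an expected range from 10000 nM to 80000 nM.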

Compound 4, half-maximal inhibitory concentration: 79000 nM
The estimate for compound 4 lay 2.8-fold (0.45 log units) below the measured number; the measured number falls inside the stated range.
By their numbers in this assay, from the lowest: compounds 2 and 3 (each within the scatter of the next); then compounds 4 and 1 (each within the scatter of the next).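

In this assay, hydroxycarbamoyl in place of 2-(hydroxycarbamoyl)ethenyl on an aromatic carbon gives a 6.1-fold higher number from compound 2 to compound 4 (0.78 log units; beyond the scatter). The earlier compounds shown here offered only a step on a saturated chain, a 4.4-fold lower number from compound 1 to compound 3 (0.65 log units; beyond the scatter), and on this aromatic carbon the shorter group again carries the higher number. Nothing in the available evidence accounts for this rise.

The compounds shown leave open whether the rise follows the length of the group or its double bond. A saturated 2-(hydroxycarbamoyl)ethyl group on the same carbon would separate the two.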